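Replacing the trichlorophenyl amide with a methylphenyl amide

A few compounds are considered here, and "the series" means these few. Any claim that something is new, unique, unknown or untested is made for them only; others in the source may bear on it.

Compound 3 `Cc1ccc(S(=O)(=O)NCc2ccc(CNC(=O)c3c(Cl)cc(Cl)cc3Cl)cc2)cc1` gives 10 nM in an assay on MDA-MB-231 cells for binding affinity to C-X-C chemokine receptor type 4 (Homo sapiens), read by immunofluorescence and microscopy, with stated times of 10 min and 30 min; a higher number here means that more compound is needed for the effect, a lower number that less compound is needed. It stands level with compound 1 `Cc1ccc(S(=O)(=O)NCc2ccc(CNC(=O)c3ccc([N+](=O)[O-])cc3)cc2)cc1`, which gives 10 nM, the two together being the lowest of the three numbers, while compound 2 `COc1ccccc1C(=O)NCc1ccc(CNS(=O)(=O)c2ccc(C)cc2)cc1` gives 100 nM. The measured steps are no change at the digits printed from compound 1 to compound 3 (within the scatter), a 10-fold higher number from compound 1 to compound 2 (1.00 log units; beyond the scatter) and a 10-fold lower number from compound 2 to compound 3 (1.00 log units; beyond the scatter). Compound 4 `Cc1ccc(C(=O)NCc2ccc(CNS(=O)(=O)c3ccc(C)cc3)cc2)cc1` differs from compound 3 by 4-methylphenyl in place of 2,4,6-trichlorophenyl on a carbonyl carbon. Going by the values given here, no measured step introduces 4-methylphenyl; the nearest guide is the 4-nitrophenyl analogue, with no change at the digits printed from compound 1 to compound 3 (within the scatter), whereas the 2-methoxyphenyl analogue shows a 10-fold lower number from compound 2 to compound 3 (1.00 log units; beyond the scatter). A small rise, within or near the scatter, is therefore expected, a 2.0-fold higher number from compound 3 to compound 4 (0.30 log units; within the scatter). Compound 4 is estimated at 20 nM, in the range 5 nM to 100 nM.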

Compound 4, effective concentration (reported as EC, without a stated level of effect): 1000 nM
Beside the measured number, compound 4's estimate is 50-fold (1.70 log units) below it; the whole stated range lies below it.
By their numbers in this assay, from the lowest: compounds 1 and 3 (each within the scatter of the next); then compound 2; then compound 4.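

In this assay, going by these compounds alone, the group on this carbonyl carbon proves far less interchangeable than the earlier compounds suggested: 4-methylphenyl in place of 2,4,6-trichlorophenyl gives a 100-fold higher number from compound 3 to compound 4 (2.00 log units; beyond the scatter), and in place of 2-methoxyphenyl it gives a 10-fold higher number from compound 2 to compound 4 (1.00 log units; beyond the scatter). Methyl in place of nitro on an aromatic carbon gives a 100-fold higher number from compound 1 to compound 4 (2.00 log units; beyond the scatter), so the match between the 4-nitrophenyl and 2,4,6-trichlorophenyl amides does not extend to this group. No evidence here explains the loss.

The compounds shown leave open how a plain phenyl, or a phenyl carrying an amine or a carboxylic acid, would read at this position.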